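Drawing the double bond as Z: compound 2 to compound 4

The source may report more compounds than this note shows. Statements on the series, on what has been measured and on what is new or still open speak of the compounds shown alone.

Measured compounds:
- compound 1, `CC(=NNC(=S)Nc1ccc(Cl)cc1)c1ccccn1`, 8.5 nM in a functional assay on MCF7 cells (Homo sapiens) for cytotoxicity, read by MTT assay, with a stated time of 48 h; on this read-out lower numbers stand for stronger inhibition and higher numbers for weaker inhibition
- compound 2, `CC(=NNC(=S)Nc1ccccc1)c1ccccn1`, 0.18 nM
- compound 3, `CC(=NNC(=S)Nc1ccccc1I)c1ccccn1`, 4.1 nM

Compound 2 gives the lowest number of the three in this assay. The nearest measured compound is compound 3, and that gap is a 23-fold higher number from compound 2 to compound 3 (1.36 log units; beyond the scatter). The furthest is compound 1, reached through a 47-fold lower number from compound 1 to compound 2 (1.67 log units; beyond the scatter). Both of these steps are substituent changes on an aromatic carbon, and both are large and beyond the scatter.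

Compound 4, `C/C(=N/NC(=S)Nc1ccccc1)c1ccccn1`, has not yet been measured. It differs from compound 2 in this way: the two compounds have the same atoms and bonds; at least one stereo element is drawn with a configuration in one of them and without one in the other: 1 of 1 stereo elements differ; a double bond is drawn without a configuration in compound 2 and Z in compound 4. No atom leaves and none enters; only the drawing of one double bond changes, from no stated configuration to Z. Neither measured step bears directly on such a change, since each of them alters a substituent rather than the way a bond is drawn. If compound 2 as measured already represents this geometry, compound 4 would be expected to give a number within the scatter of compound 2. The step expected in this assay is therefore no change at the digits printed from compound 2 to compound 4 (within the scatter), none beyond the scatter.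

Compound 4 is estimated at 0.18 nM in this assay, with a range from 0.06 nM to 0.6 nM.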

Compound 4, half-maximal inhibitory concentration: 0.18 nM
Beside the measured number, compound 4's estimate shows no gap at the digits printed, and the stated range covers the measured number.
By their numbers in this assay, from the lowest: compounds 2 and 4 (each within the scatter of the next); then compound 3; then compound 1.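

In this assay, the series now includes a change that touches no atom, and the result is no change at the digits printed from compound 2 to compound 4 (within the scatter). The two earlier steps, a 47-fold lower number from compound 1 to compound 2 (1.67 log units; beyond the scatter) and a 23-fold higher number from compound 2 to compound 3 (1.36 log units; beyond the scatter), each changed a substituent on an aromatic carbon and moved the number well beyond the scatter, whereas stating the configuration of this double bond as Z leaves the reading of compound 2 in place. This does not amount to a comparison of two geometries, since only one of the two drawings carries a configuration, and the agreement may mean no more than that the same form was tested, which is what limits the reading here: the fact that one of compounds 2 and 4 is drawn with a defined configuration and the other without, at the place where they differ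

The compounds shown leave open what the double bond drawn as E would give in this series. They also leave open how the number would respond to a methoxy group or an amine on the aromatic ring, or to a carbonyl in place of the thiocarbonyl of the shared core.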